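Replacing the chain sulfur in the acid side chain

The source may hold more compounds than are shown below. What is called first, only, known or untested is meant among the compounds shown, and "the series" means these compounds.

Three compounds of the series have numbers in a functional assay with prostaglandin E2 receptor EP4 subtype (Homo sapiens) as the target; a higher number here means that more compound is needed for the effect, a lower number that less compound is needed. Compound 1 `O=C(O)CCCSCCN1C(=O)CCC[C@@H]1/C=C/[C@@H](O)CCC1CCC1` gives 34 nM, compound 2 `O=C(O)CCCSCCN1C(=O)CCC[C@@H]1/C=C/C(O)C1(c2ccccc2)CC1` gives 260 nM, and compound 3 `COCc1cccc(C[C@H](O)/C=C/[C@H]2CCCC(=O)N2CCSCCCC(=O)O)c1` gives 44 nM. Compound 3 thus stands second highest of the three. Its nearest neighbour is compound 1, and the recorded step a 1.3-fold higher number from compound 1 to compound 3 (0.11 log units; within the scatter) lies within the scatter. For the measured compounds named here, compound 2 is furthest from compound 3, its number sitting beyond the scatter above that of compound 3; no single-point step is recorded for that pair.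

Compound 4 `COCc1cccc(C[C@H](O)/C=C/[C@H]2CCCC(=O)N2CCCCCCC(=O)O)c1` has not been measured. It differs from compound 3 by 4-carboxybutyl in place of (3-carboxypropyl)sulfanyl on a saturated chain carbon, two bonds along the chain from an amide-type nitrogen in a ring. Going by the values given here, none of the measured steps touches this part of the molecule: the only recorded step, from compound 1 to compound 3, changes a different part of the structure, and compound 2 also differs from the others elsewhere. Among the compounds with values here, there is therefore no series-internal precedent for the exchange of sulfur for carbon in the acid-bearing chain. The expectation is a step of a 1.4-fold higher number from compound 3 to compound 4 (0.13 log units; within the scatter) from compound 3, small and in no firm direction, with a wide range to cover the absence of precedent. Compound 4 is accordingly estimated at 60 nM in this assay, with a range from 15 nM to 250 nM.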

Compound 4, half-maximal effective concentration: 44 nM
Compound 4: middle estimate off by 1.4-fold (0.13 log units), on the high side, within the range that was stated.
By their numbers in this assay, from the lowest: compounds 1, 3 and 4 (each within the scatter of the next); then compound 2.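

In this assay, the exchange at this position, 4-carboxybutyl in place of (3-carboxypropyl)sulfanyl on a saturated chain carbon, two bonds along the chain from an amide-type nitrogen in a ring, gives no change at the digits printed from compound 3 to compound 4 (within the scatter). All three earlier compounds carry the chain sulfur, so they could not show what its removal does; this pair shows that, with the 3-(methoxymethyl)phenyl group in place, the sulfur-containing and all-carbon acid chains cannot be told apart in this assay. No supporting data bear on why the exchange leaves the two compounds indistinguishable here.

Going by these compounds, whether the all-carbon chain behaves the same way with the cyclobutylmethyl group of compound 1, or with the group carried by compound 2, remains open, as a single pair on one background cannot settle it. Also open, on these data alone, is how this assay responds to an ether oxygen in place of the chain sulfur, to a longer or shorter acid-bearing chain, or to a tetrazole in place of the carboxylic acid.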